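Chlorine on the benzyl ring of a cyclodepsipeptide

The source may report more compounds than this note shows. Statements on the series, on what has been measured and on what is new or still open speak of the compounds shown alone.

Measured so far:
- compound 1, `C/C=C(\C)[C@H]1OC(=O)[C@@H](C)NC(=O)[C@H]([C@@H](C)CC)NC(=O)CN(C)C(=O)[C@@H](Cc2ccccc2)N(C)C(=O)[C@H](C)NC(=O)[C@@H](CC(C)C)OC(=O)/C(C)=C/C[C@H](O)[C@@H]1C`: 0.0021 nM
- compound 2, `C/C=C(\C)[C@@H](O)[C@@H](C)[C@@H]1C/C=C(\C)C(=O)O[C@H](CC(C)C)C(=O)N[C@@H](C)C(=O)N(C)[C@H](Cc2ccccc2)C(=O)N(C)CC(=O)N[C@@H]([C@@H](C)CC)C(=O)N[C@H](C)C(=O)O1`: 0.0014 nM
- compound 3, `C/C=C(\C)[C@H]1OC(=O)[C@@H](C)NC(=O)[C@H]([C@@H](C)CC)NC(=O)CN(C)C(=O)[C@@H](Cc2ccc(Cl)cc2)N(C)C(=O)[C@H](C)NC(=O)[C@@H](CC(C)C)OC(=O)/C(C)=C/C[C@H](O)[C@@H]1C`: 0.00001 nM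

The three measured compounds were tested in a functional assay on A549 cells (Homo sapiens) for cytotoxicity, read by CellTiter-Blue, with a stated time of 72 h; on this read-out higher numbers stand for weaker inhibition and lower numbers for stronger inhibition. Compound 1 and compound 2 share the same atoms joined differently; the difference between the two cores is not broken down here. In this assay compound 1 gives 0.0021 nM and compound 2 gives 0.0014 nM, two numbers that lie within the usual scatter of each other, so nothing separates them.

Compound 3 is compound 1 with one change, (chloro in place of hydrogen on an aromatic carbon). This single change made a large step: a 210-fold lower number from compound 1 to compound 3 (2.32 log units; beyond the scatter). Among the three measured compounds, compound 3 is the one whose steps to both others lie beyond the scatter.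

Compound 4, `C/C=C(\C)[C@@H](O)[C@@H](C)[C@@H]1C/C=C(\C)C(=O)O[C@H](CC(C)C)C(=O)N[C@@H](C)C(=O)N(C)[C@H](Cc2ccc(Cl)cc2)C(=O)N(C)CC(=O)N[C@@H]([C@@H](C)CC)C(=O)N[C@H](C)C(=O)O1`, has not yet been measured. It stands to compound 2 as compound 3 stands to compound 1: the change is chloro in place of hydrogen on an aromatic carbon, and the place described for it is the same, word for word, as for the earlier change, so it is the same change made on the other core.

The expectation for compound 4 rests on one thing only: the step seen on the core of compound 1, because a 210-fold lower number from compound 1 to compound 3 (2.32 log units; beyond the scatter) was large and the cores of compound 1 and compound 2 gave numbers within the scatter of each other. The step from compound 2 to compound 4 is therefore expected to be about a 200-fold lower number from compound 2 to compound 4 (2.30 log units; beyond the scatter). For compound 4 the estimate in this assay is 0.000007 nM, with a likely range from 0.000001 nM to 0.00005 nM.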

Compound 4, half-maximal inhibitory concentration: 0.00002 nM
The estimate for compound 4 lay 2.9-fold (0.46 log units) below the measured number; measured number inside the range.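

In this assay, chloro in place of hydrogen on the aromatic ring gave a large step on the second core as well, a 70-fold lower number from compound 2 to compound 4 (1.85 log units; beyond the scatter), so the direction of the change carried over from one core to the other. The size of the step did not carry over exactly, and the gap between the two steps is larger than the scatter of repeated measurements allows: the same change on two cores in this assay, a 210-fold lower number (2.32 log units; beyond the scatter) from compound 1 to compound 3 and a 70-fold lower number (1.85 log units; beyond the scatter) from compound 2 to compound 4, 3.0-fold (0.48 log units) apart, beyond the scatter of two such steps These two pairs show that the benzyl to 4-chlorobenzyl change kept its direction on both cores, but they do not show why the step differs in size, and they cannot predict how large it would be on any further core.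

The compounds shown carry only hydrogen or chloro at this place on the ring, so it remains open how a fluoro, a bromo, a methoxy or an amine in the same place would compare. On these data alone, it also remains open whether the large step from this change would appear in any test other than this assay.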